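The source may report more compounds than this note shows. Statements on the series, on what has been measured and on what is new or still open speak of the compounds shown alone.

Measured compounds:
- compound 1 `Cn1c(/C=C2\SC(=O)N(CC(=O)Nc3cc(C(C)(C)C)on3)C2=O)nc2ccccc21` gives 31400 nM in a functional assay on DU-145 cells (Homo sapiens) for inhibition, read by MTT assay, with a stated time of 48 h; on this read-out higher numbers stand for weaker inhibition and lower numbers for stronger inhibition
- compound 2 `CC(C)n1c(/C=C2\SC(=O)N(CC(=O)Nc3cc(C(C)(C)C)on3)C2=O)nc2ccccc21` gives > 50000 nM in this assay; this is a limit of the assay, not a number
- compound 3 `Cn1c(/C=C2\SC(=O)N(CC(=O)Nc3nc(-c4ccccc4)cs3)C2=O)nc2ccccc21` gives 31400 nM in this assay

Compound 1 stands level with compound 3 at the digits shown, and the step of no change at the digits printed from compound 1 to compound 3 (within the scatter) is within the scatter. The step of an at least 1.5-fold higher number from compound 1 to compound 2 (0.20 log units; that floor lies within the scatter) runs to a limit (the limit of > 50000 nM in this assay, at which 1 of the 3 values shown sits), so its true size is not fixed.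

Compound 4 `Cn1c(/C=C2\SC(=O)N(CC(=O)N3CCCC3)C2=O)nc2ccccc21` is to be measured. It differs from compound 1 by pyrrolidin-1-yl in place of (5-(tert-butyl)-1,2-oxazol-3-yl)amino on a carbonyl carbon. Among the measured compounds shown here, no measured step touches this exact change; the nearest is the exchange of one aromatic amine for another, which gave no change at the digits printed from compound 1 to compound 3 (within the scatter) and so left the read-out unmoved. The present change goes further, trading an aromatic amino group for a saturated ring without donor or acceptor, so the expectation carries wide uncertainty. On balance a step of about a 1.2-fold higher number from compound 1 to compound 4 (0.08 log units; within the scatter) is expected, a little toward higher numbers, but not clearly beyond the scatter. Compound 4 is therefore estimated at 38000 nM, with a range from 12000 nM to 120000 nM.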

Compound 4, half-maximal inhibitory concentration: > 50000 nM
Compound 4 ended at the assay's limit; the forecaster's own chance of this, stated with the estimate: 35%; at least 1.3-fold (0.11 log units) between middle value and limit.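

The exchange on the carbonyl carbon gives an at least 1.5-fold higher number from compound 1 to compound 4 (0.20 log units; that floor lies within the scatter) in this assay, so no gain in inhibition appears on leaving the aromatic amine series for pyrrolidin-1-yl. Compound 4 gives > 50000 nM, which is a limit of the assay and not a number. Compound 3 had shown only that one aromatic amino group could replace another without a read-out change, whereas this step loses both the amide hydrogen and the aromatic ring at once, and its true size remains unfixed: the limit of > 50000 nM in this assay, at which 2 of the 4 values shown sit.

Which of these two losses matters stays open, since both leave together in compound 4. A cyclopentylamino group on the carbonyl carbon would keep the amide hydrogen without the aromatic ring, and so would separate the two.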